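Methoxy to Hydroxy at the Edge of an Assay

The source may report more compounds than this note shows. Statements on the series, on what has been measured and on what is new or still open speak of the compounds shown alone.

Compound 1 `COc1cc(/C=C/c2ccc(OC(F)(F)F)cc2)ccc1/C=C/c1ccc(OC(F)(F)F)cc1`: > 7
Compound 2 `COc1cc(/C=C/c2ccc(C(F)(F)C(F)F)cc2)ccc1/C=C/c1ccc(C(F)(F)C(F)F)cc1`: > 7
Compound 3 `Oc1cc(/C=C/c2ccc(OC(F)(F)F)cc2)ccc1/C=C/c1ccc(OC(F)(F)F)cc1`: > 7

All three measured compounds were run in a physicochemical assay for lipophilicity, read by HPLC; a higher number here means a more lipophilic compound, a lower number a more polar compound. For compound 1 the reported value > 7 is a limit of the assay, not a number. For compound 2 the value > 7 is likewise a limit. For compound 3 the value > 7 is again a limit.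

Compound 3 is made from compound 1 by one change, (hydrogen in place of methyl on an oxygen on an aromatic ring). The resulting step, a step that the two limits leave unreadable from compound 1 to compound 3, cannot be read, because the limit of > 7 in this assay, at which 3 of the 3 values shown sit: both ends of the step sit at that limit, so nothing about its size or direction is visible.

Compound 2 and compound 1 share the same central arrangement but carry different groups on the outer rings; the difference between the two cores is not broken down here.

Compound 4 `Oc1cc(/C=C/c2ccc(C(F)(F)C(F)F)cc2)ccc1/C=C/c1ccc(C(F)(F)C(F)F)cc1` is not yet measured. It stands to compound 2 exactly as compound 3 stands to compound 1: the change is hydrogen in place of methyl on an oxygen on an aromatic ring, at the same place, so it is the same change. For the measured compounds named here, since the only precedent is the unreadable step from compound 1 to compound 3, and compound 2 itself already sits at the limit, the step from compound 2 to compound 4 is expected to be a step that the limit leaves unreadable from compound 2 to compound 4 and most likely to leave compound 4 at the limit as well. Compound 4 is therefore estimated at 7.3, within a range from 6.7 to 7.9.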

Compound 4, partition coefficient: > 7
Compound 4 was reported as a limit; the forecaster's own chance of this, stated with the estimate: 85%; the middle value does not contradict the limit.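

In this assay compound 4 gives > 7, which is a limit and not a number. The change from compound 2 to compound 4 therefore yields no readable step, because both of its ends are limits: the limit of > 7 in this assay, at which 4 of the 4 values shown sit.

The compounds shown leave open both the size and the direction of any shift in this read-out on going from methoxy to hydroxy.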